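The source may hold more compounds than are shown below. What is called first, only, known or untested is meant among the compounds shown, and "the series" means these compounds.

Measured compounds:
compound 1, `O=C1NC(=S)S/C1=C\C=C\c1ccccc1OCc1ccccc1C(F)(F)F`, 80%
compound 2, `COc1ccccc1/C=C/C=C1\SC(=S)NC1=O`, 69%

In a functional assay on DLD-1 cells (Homo sapiens), read by microscopy and crystal violet staining, with a stated time of 20 h, tested at 10 ug/mL (on this read-out higher numbers stand for more inhibition at the one concentration tested (going by the name of the read-out) and lower numbers for less inhibition), compound 2 stands lowest of the two numbers, with compound 1 giving 80%, a value higher by an amount beyond the usual scatter. Compound 3, `O=C1NC(=S)S/C1=C\C=C\c1ccccc1OCc1ccccc1`, has not been measured in this assay. It differs from compound 2 by phenyl in place of hydrogen on a saturated chain carbon bound to an oxygen on an aromatic ring. Compound 3 is expected to give a small upward step, a number 6 percentage points higher from compound 2 to compound 3 (within the scatter), likely not beyond the scatter, since compound 1 carries a related benzyloxy group and gives 80%. Compound 3 is therefore estimated at 75%, with a range from 60% to 90%.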

Compound 3, a percentage reported as inhibition, at one concentration (the size of the read-out at that concentration, not a potency): 65%
For compound 3 the middle estimate is 10 percentage points above the measured one; measured number inside the range.
By their numbers in this assay, from the lowest: compounds 3 and 2 (each within the scatter of the next); then compound 1.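

In this assay, going from methoxy to benzyloxy gives a number 4 percentage points lower from compound 2 to compound 3 (within the scatter), so the added phenyl alone does not separate these two compounds. Placing hydrogen where trifluoromethyl stood on an aromatic carbon gives a number 15 percentage points lower from compound 1 to compound 3 (beyond the scatter), so within this pair the difference follows the trifluoromethyl rather than the benzyloxy group by itself. Nothing available here explains either step. The compounds shown leave open whether a fluorine, a nitrile or an amine on that aromatic carbon would match trifluoromethyl, and whether a longer chain on the oxygen would behave as benzyl does.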